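Azetidine nitrogen substitution in a bis-sulfonyl piperidine series

This account rests on a few compounds, and the source may have more. Where it says the series, first, only, none or still open, it means among the compounds named here.

Measured so far:
compound 1 `CCN(CC)S(=O)(=O)c1ccc(S(=O)(=O)N2CCC[C@@H](C(=O)NC3CN(C(=O)OC(C)(C)C)C3)C2)cc1` — 1800 nM
compound 2 `CCOC(=O)[C@@H]1CCCN(S(=O)(=O)c2ccc(S(=N)(=O)N(CC)CC)cc2)C1` — 3600 nM
compound 3 `CCOC(=O)C1CCN(S(=O)(=O)c2ccc(S(=O)(=O)N(CC)CC)cc2)CC1` — 23100 nM

In a functional assay on BXPC-3 cells (Homo sapiens) for inhibition, read by MTT assay, with a stated time of 7 days (on this read-out lower numbers stand for stronger inhibition and higher numbers for weaker inhibition), compound 1 gives 1800 nM and stands at the low end of the three numbers. The nearest number is that of compound 2, whose 3600 nM lies within the scatter of compound 1, so the two cannot be ordered. Compound 3 gives 23100 nM, a gap from compound 1 that lies beyond the scatter. For the measured compounds named here, no pair of measured compounds differs in one place only, so no single-change step is available from the measured set.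

Compound 4 `CCN1CC(NC(=O)[C@@H]2CCCN(S(=O)(=O)c3ccc(S(=O)(=O)N(CC)CC)cc3)C2)C1` has not yet been measured. It differs from compound 1 by ethyl in place of tert-butoxycarbonyl on an amine nitrogen in a ring: tert-butoxycarbonyl leaves and ethyl enters on an amine nitrogen in a ring of the four-membered non-aromatic ring, two ring bonds from the ring atom that bears a large group. Going by the values given here, no measured pair shows this change, so the expectation rests on compound 1 alone. The step of a 1.4-fold higher number from compound 1 to compound 4 (0.14 log units; within the scatter) is expected to be small, of uncertain direction, and not clearly beyond the scatter. Compound 4 is estimated at 2500 nM, with a range of 600 nM to 10000 nM.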

Compound 4, half-maximal inhibitory concentration: > 30000 nM
Compound 4 was reported as a limit; the forecaster's own chance of this, stated with the estimate: 5%; middle value at least 12-fold (1.07 log units) from the limit.
By their numbers in this assay, from the lowest: compounds 1 and 2 (each within the scatter of the next); then compound 3. At a limit, above all of these: compound 4.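

In this assay the exchange of tert-butoxycarbonyl for ethyl on the amine nitrogen in the four-membered non-aromatic ring gives an at least 16-fold higher number from compound 1 to compound 4 (1.22 log units; beyond the scatter) and is the only single-change step shown in the series. The group on this nitrogen therefore matters: with the rest of compound 1 unchanged, tert-butoxycarbonyl gives a measured number, whereas ethyl gives none within the assay's range. The result for compound 4 is a limit, so the step fixes only a lower bound on the size of this change: the limit of > 30000 nM in this assay, at which 1 of the 4 values shown sits.

A single pair leaves open which part of the tert-butoxycarbonyl group carries the difference. Also open, on these data alone, is whether an acetyl group, a methanesulfonyl group, a benzyl group or the free amine on this nitrogen would read closer to compound 1 or to compound 4.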